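A few compounds are considered here, and "the series" means these few. Any claim that something is new, unique, unknown or untested is made for them only; others in the source may bear on it.

Three amines on the shared core have been read so far in a functional assay on HeLa cells (Homo sapiens) for inhibition, with a stated time of 72 h; a higher number here means that more compound is needed for the effect, a lower number that less compound is needed. Compound 1 (`COc1cc(CNc2nc[nH]n2)ccc1OCc1ccc(Cl)nc1`) gives 69000 nM, compound 2 (`COCCNCc1ccc(OCc2ccc(Cl)nc2)c(OC)c1`) gives 97000 nM, and compound 3 (`COc1cc(CNCC2CCCO2)ccc1OCc1ccc(Cl)nc1`) gives 66000 nM. Compound 3 therefore lies within the scatter of both other compounds.

The next entry is compound 4 (`COc1cc(CNCc2cccs2)ccc1OCc1ccc(Cl)nc1`), with thiophen-2-yl in place of oxolan-2-yl on a saturated chain carbon bound to an amine nitrogen. Among the compounds with values here, no measured step makes this exact exchange, and thiophen-2-yl has not yet been read. The closest evidence is the change at the same place, a 1.5-fold lower number from compound 2 to compound 3 (0.17 log units; within the scatter). The two changes on the amine nitrogen, a 1.4-fold higher number from compound 1 to compound 2 (0.15 log units; within the scatter) and a 1.0-fold lower number from compound 1 to compound 3 (0.02 log units; within the scatter), bear on it less directly. All three steps stay within the scatter, so no step beyond the scatter is expected in this assay.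

The expected step is a 1.1-fold lower number from compound 3 to compound 4 (0.06 log units; within the scatter). For compound 4 the estimated value is 58000 nM, with an expected range of 25000 nM to 110000 nM.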

Compound 4, half-maximal effective concentration: 96000 nM
Compound 4: middle estimate off by 1.7-fold (0.22 log units), on the low side; the measured number falls inside the stated range.
By their numbers in this assay, from the lowest: compounds 3, 1, 4 and 2 (each within the scatter of the next).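

In this assay, the aromatic thiophen-2-yl on a saturated chain carbon bound to an amine nitrogen reads the same as the non-aromatic oxolan-2-yl (a 1.5-fold higher number from compound 3 to compound 4 (0.16 log units; within the scatter)) and the open methoxymethyl (a 1.0-fold lower number from compound 2 to compound 4 (0.00 log units; within the scatter)). The exchange on the amine nitrogen also stays within the scatter (a 1.4-fold higher number from compound 1 to compound 4 (0.14 log units; within the scatter)), so these four amines on the shared core, now including a sulfur-containing aromatic ring, cannot be separated in this assay. Nothing at hand offers an explanation for this flat reading.

Going by these compounds, whether a carboxylic acid, a phenyl ring or a longer chain on the amine nitrogen would step beyond the scatter remains open. Also open, on these data alone, is whether any change to the shared core itself would move these numbers.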